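A few compounds are considered here, and "the series" means these few. Any claim that something is new, unique, unknown or untested is made for them only; others in the source may bear on it.

Three compounds share one core and differ only in a single aromatic substituent. Compound 1 `COc1ccc(-c2nc(SCC(=O)c3sc(-c4ccccc4)nc3C)nc(N)c2C#N)cc1` gives 68.8% in a functional assay on U-87MG ATCC cells for antiproliferative activity against U-87 MG (Homo sapiens), read by MTT assay, with a stated time of 48 h, tested at 5 uM; a lower number here means a stronger effect, a higher number a weaker effect of the compound at the concentration tested; compound 2 `Cc1nc(-c2ccccc2)sc1C(=O)CSc1nc(N)c(C#N)c(-c2ccc(Cl)cc2)n1` gives 62.9%; and compound 3 `Cc1nc(-c2ccccc2)sc1C(=O)CSc1nc(N)c(C#N)c(-c2ccccc2)n1` gives 103%. Compound 3 carries the highest number of the three and so shows the weakest effect: the step of a number 34.2 percentage points higher from compound 1 to compound 3 (beyond the scatter) and the step of a number 40.1 percentage points higher from compound 2 to compound 3 (beyond the scatter) both lie beyond the scatter, whereas a number 5.9 percentage points lower from compound 1 to compound 2 (within the scatter) does not. Compound 4 `Cc1nc(-c2ccc(Cl)cc2)sc1C(=O)CSc1nc(N)c(C#N)c(-c2ccccc2)n1` is reached from compound 3 by one change: chloro in place of hydrogen on an aromatic carbon. This change sits on an aromatic carbon of a different ring of the shared core than the one altered in the measured steps, so none of them bears on it directly. The guidance is only indirect: wherever chloro or methoxy stood in place of hydrogen, as in compound 1 and compound 2, the number was markedly lower than in compound 3. A chloro on this other ring may behave alike, or may not, so a drop of moderate size is expected, with wide uncertainty around it. For compound 4 the expected step is a number 18 percentage points lower from compound 3 to compound 4 (beyond the scatter). The estimate for compound 4 in this assay is 85%, ranging from 55% to 110%.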

Compound 4, a percentage reported as activity, at one concentration (the size of the read-out at that concentration, not a potency): 71.1%
Compound 4: the middle estimate sits 13.9 percentage points above what was measured, within the range that was stated.
By their numbers in this assay, from the lowest: compounds 2, 1 and 4 (each within the scatter of the next); then compound 3.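

In this assay, the change from phenyl to 4-chlorophenyl gives a number 31.9 percentage points lower from compound 3 to compound 4 (beyond the scatter) and is large, so this place, para to a large group on a six-membered aromatic ring of carbon only, responds to a single added chlorine atom. The earlier steps shown here concerned only the other aromatic ring of the shared core, as in a number 40.1 percentage points higher from compound 2 to compound 3 (beyond the scatter), so a second ring of compound 3 now also proves able to move the read-out beyond the scatter when a hydrogen is replaced. The data offer no measurement that accounts for this effect of the chloro group, and so the step records what happens without telling why.

The compounds shown leave open whether a methoxy group, a fluoro group or an amine at this same place would lower the number as the chloro group does, and whether a carboxylic acid or a longer chain would be tolerated there. They also leave open what happens when a chloro group stands on both aromatic rings at once, and whether the two changes would add up.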